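Methyl added to the cyanophenoxy carbamate: compound 3

A few compounds are considered here, and "the series" means these few. Any claim that something is new, unique, unknown or untested is made for them only; others in the source may bear on it.

In an assay on isolated protein for inhibition of Fatty-acid amide hydrolase 1 (Rattus norvegicus), read by fluorescence (a higher number here means a weaker inhibitor, a lower number a stronger inhibitor), compound 2 `N#Cc1cccc(OC(=O)N2CCC(C(c3ccccc3)c3ccccc3)CC2)c1` reaches only the assay limit, giving > 1000 nM. Compound 1 `N#Cc1ccc(F)c(OC(=O)N2CCC(C(c3ccccc3)c3ccccc3)CC2)c1` likewise reports a limit in this assay, > 1000 nM. The step that the two limits leave unreadable from compound 1 to compound 2 therefore has no readable size, and the limit of > 1000 nM in this assay, at which 2 of the 2 values shown sit, is all that the measured pair shows. Compound 3 `Cc1cc(C#N)cc(OC(=O)N2CCC(C(c3ccccc3)c3ccccc3)CC2)c1` differs from compound 2 by methyl in place of hydrogen on an aromatic carbon. Among the measured compounds shown here, no measured step bears on this change, and both measured values sit at the limit, so nothing beyond the scatter can be read from them. The step that the limit leaves unreadable from compound 2 to compound 3 is an estimate only. Compound 3 is expected to give about 3000 nM, within 700 nM to 20000 nM, most probably again as a limit.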

Compound 3, half-maximal inhibitory concentration: > 1000 nM
Compound 3 ended at the assay's limit; the forecaster's own chance of this, stated with the estimate: 80%; the middle value does not contradict the limit.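

No new step can be read among compound 1, compound 2 and compound 3 in this assay, as each reports only a limit: the limit of > 1000 nM in this assay, at which 3 of the 3 values shown sit.

From the compounds shown here alone, whether methyl or fluoro on the cyanophenyl group alters inhibition at all remains open.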